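The compounds below may be only part of what the source reports. "The series", "measured", "known", "first", "only" and "open" are said of these compounds alone.

Measured in a functional assay on A549 cells (Homo sapiens) for cytotoxicity, read by MTT assay, with a stated time of 48 h; a higher number here means a weaker inhibitor, a lower number a stronger inhibitor:
compound 1 `Cc1cccc(/C=C/[C@](C)(O)CC[C@@H]2[C@@]3(C)CCCC(C)(C)[C@@H]3CC[C@@]2(C)O)c1C` gives 3800 nM
compound 2 `COc1cccc(/C=C/[C@](C)(O)CC[C@@H]2[C@@]3(C)CCCC(C)(C)[C@@H]3CC[C@@]2(C)O)c1OC` gives 3280 nM

Compound 2, at 3280 nM, cannot be separated from compound 1 on these numbers. The gap between them is a 1.2-fold lower number from compound 1 to compound 2 (0.06 log units; within the scatter). Compound 3 `CC1(C)CCC[C@]2(C)[C@@H](CC[C@@](C)(O)/C=C/c3ccc(Br)cc3)[C@](C)(O)CC[C@@H]12` keeps the shared core and changes only the aryl group, with 4-bromophenyl in place of 2,3-dimethoxyphenyl on a double-bonded chain carbon bound to a double-bonded chain carbon. Among the measured compounds shown here, the only measured exchange at this place is that same step, a 1.2-fold lower number from compound 1 to compound 2 (0.06 log units; within the scatter), which is small. For the measured compounds named here, no measured compound carries a 4-bromophenyl, so this guide is weak and the range stays wide. In this assay no shift beyond the scatter is expected, and the expected step is a 1.1-fold lower number from compound 2 to compound 3 (0.04 log units; within the scatter). For compound 3 the estimated value is 3000 nM, with an expected range of 1200 nM to 7500 nM.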

Compound 3, half-maximal inhibitory concentration: 43200 nM
Estimate against measurement, compound 3: 14-fold (1.16 log units) below, and the stated range ends below it.
By their numbers in this assay, from the lowest: compounds 2 and 1 (each within the scatter of the next); then compound 3.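

In this assay, the aryl group on the double-bonded chain carbon proves to be a position that can matter: 4-bromophenyl gives a 13-fold higher number from compound 2 to compound 3 (1.12 log units; beyond the scatter) and an 11-fold higher number from compound 1 to compound 3 (1.06 log units; beyond the scatter), whereas the exchange between 2,3-dimethylphenyl and 2,3-dimethoxyphenyl stayed within the scatter. The 4-bromophenyl group differs from both of those groups in its substituent and in the numbering of that substituent on the ring, and these three compounds cannot separate the two changes. No measurement at hand accounts for the higher number of compound 3.

Open, from the compounds shown here alone, is whether a 4-methoxyphenyl or a 4-methylphenyl group would stay with compound 2 and compound 1 or move with compound 3, and likewise a 2,3-dibromophenyl group. An unsubstituted phenyl group would give the series a reference for all three aryl groups.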